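A few compounds are considered here, and "the series" means these few. Any claim that something is new, unique, unknown or untested is made for them only; others in the source may bear on it.

Measured compounds in an assay on HEK293 cells for displacement of a labelled ligand from NPC1-like intracellular cholesterol transporter 1 (Homo sapiens); a higher number here means a weaker inhibitor, a lower number a stronger inhibitor:
Compound 1 `CC(C)(C)c1ccc(C(=O)N2CCC3(CC2)C(=O)N(CC(=O)NCCO)CN3c2ccccc2)cc1` gives 1000 nM.
Compound 2 `CC(C)(C)c1ccc(C(=O)N2CCC3(CC2)C(=O)N(CC(=O)NCCCN)CN3c2ccccc2)cc1` gives 4200 nM.
Compound 3 `CC1(C)CC(OC(=O)CN2CN(c3ccccc3)C3(CCN(C(=O)c4ccc(C(C)(C)C)cc4)CC3)C2=O)CC(C)(C)N1` gives 1300 nM.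

Compound 3 stands second highest of the three values in this assay; its nearest neighbour is compound 1, and the step of a 1.3-fold higher number from compound 1 to compound 3 (0.11 log units; within the scatter) lies within the scatter, so the two cannot be ordered. Compound 2 is furthest, with a 3.2-fold lower number from compound 2 to compound 3 (0.51 log units; beyond the scatter).

Compound 4 `CC(C)(C)c1ccc(C(=O)N2CCC3(CC2)C(=O)N(CC(=O)N2CCC(O)CC2)CN3c2ccccc2)cc1` is not yet measured. It differs from compound 3 in one place: 4-hydroxypiperidin-1-yl in place of (2,2,6,6-tetramethylpiperidin-4-yl)oxy on a carbonyl carbon. Among the compounds with values here, the steps that bear on this are those into compound 3 from the two other amide-type side chains. Compound 1 carries a (2-hydroxyethyl)amino on the same carbonyl carbon and differs from compound 3 only within the scatter; compound 2 carries a (3-aminopropyl)amino there and gives the higher number. Compound 4 keeps a hydroxy group on a ring that is joined to the carbonyl through nitrogen, which resembles compound 1 more than compound 2. With two of three side chains on this carbonyl giving numbers within the scatter of each other, no step beyond the scatter is expected from compound 3 to compound 4 in this assay, and the expected step is a 1.2-fold lower number from compound 3 to compound 4 (0.07 log units; within the scatter). Compound 4 is therefore estimated at 1100 nM, with a range from 450 nM to 2800 nM.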

Compound 4, half-maximal inhibitory concentration: 4700 nM
Beside the measured number, compound 4's estimate is 4.3-fold (0.63 log units) below it; the measured number lies above the stated range.
By their numbers in this assay, from the lowest: compounds 1 and 3 (each within the scatter of the next); then compounds 2 and 4 (each within the scatter of the next).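

A hydroxy group on the side chain does not by itself hold the number on this carbonyl carbon: in this assay, 4-hydroxypiperidin-1-yl in place of (2-hydroxyethyl)amino gives a 4.7-fold higher number from compound 1 to compound 4 (0.67 log units; beyond the scatter) and so separates two hydroxy-bearing side chains. A six-membered non-aromatic ring with one hetero atom is not enough either, since 4-hydroxypiperidin-1-yl in place of (2,2,6,6-tetramethylpiperidin-4-yl)oxy gives a 3.6-fold higher number from compound 3 to compound 4 (0.56 log units; beyond the scatter) even though both groups carry such a ring. Against the primary amine side chain, 4-hydroxypiperidin-1-yl in place of (3-aminopropyl)amino gives a 1.1-fold higher number from compound 2 to compound 4 (0.05 log units; within the scatter) and the two cannot be ordered, so the four side chains now fall into two sets, compounds 1 and 3 with the lower numbers and compounds 2 and 4 with the higher.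

The compounds shown leave open whether the ring hydroxy contributes at all, and a plain piperidin-1-yl or a morpholin-4-yl on the same carbonyl carbon would bear on that. They also leave open how a carboxylic acid or a longer hydroxyalkyl chain on the amide nitrogen would read against compound 1.

No available evidence accounts for these steps.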